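The compounds below may be only part of what the source reports. "The series", "measured", "known", "first", "only" and "open" are said of these compounds alone.

Compound 1 `Cc1ccc(-c2nnc(N3CCN(C(=O)CN4CCN(c5ccccc5)CC4)CC3)nc2-c2ccc(C)cc2)cc1` in an ADME assay on NIH3T3 cells (Mus musculus) for cytotoxicity, read by MTT assay, with a stated time of 24 h (on this read-out higher numbers stand for weaker inhibition and lower numbers for stronger inhibition), reaches only the limit of > 914000 nM.
Compound 2 `Cc1ccc(-c2nnc(N3CCN(C(=O)CN4CCN(c5ccccc5Cl)CC4)CC3)nc2-c2ccc(C)cc2)cc1` in this assay likewise reaches only the limit of > 859000 nM.
Among the compounds with values here, compound 3 `Cc1ccc(-c2nnc(N3CCN(C(=O)CN4CCN(c5cccc(Cl)c5)CC4)CC3)nc2-c2ccc(C)cc2)cc1` in this assay gives 859000 nM, the only actual number among the three.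

Compound 4 `COc1ccc(N2CCN(CC(=O)N3CCN(c4nnc(-c5ccc(C)cc5)c(-c5ccc(C)cc5)n4)CC3)CC2)cc1` differs from compound 3 by 4-methoxyphenyl in place of 3-chlorophenyl on an amine nitrogen in a ring. Of the measured steps, an at least 1.0-fold lower number from compound 1 to compound 3 (0.02 log units; that floor lies within the scatter) is the only one with a readable size, and it lies within the scatter; a step that the two limits leave unreadable from compound 1 to compound 2 and a number no higher from compound 2 to compound 3 (the limit leaves the size open) stay unreadable because of the limit of > 859000 nM in this assay, at which 1 of the 3 values shown sits, and (the limit of > 914000 nM in this assay, at which 1 of the 3 values shown sits). Nothing here points to a step beyond the scatter in this assay when one aryl group on the ring nitrogen is exchanged for another. Compound 4 is therefore expected to give about 900000 nM, between 450000 nM and 1800000 nM. That expectation means a step of a 1.0-fold higher number from compound 3 to compound 4 (0.02 log units; within the scatter).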

Compound 4, half-maximal inhibitory concentration: 116000 nM
Compound 4: middle estimate off by 7.8-fold (0.89 log units), on the high side, outside the stated range (below it).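

Within the data shown here, exchanging 3-chlorophenyl for 4-methoxyphenyl on the ring nitrogen gives the first change at this position that clearly exceeds the scatter in this assay (a 7.4-fold lower number from compound 3 to compound 4 (0.87 log units; beyond the scatter)). The comparisons with the other two compounds point the same way (an at least 7.4-fold lower number from compound 2 to compound 4 (0.86 log units; beyond the scatter)) and (an at least 7.8-fold lower number from compound 1 to compound 4 (0.89 log units; beyond the scatter)). Compound 1 and compound 2 each stand at a limit of the assay, so those two steps are only floors.

Compound 4 differs from compound 3 in both the substituent and its place on the phenyl ring, and the compounds shown cannot separate these two changes. From the compounds shown here alone, how a hydroxy group or an amine on that phenyl ring would read also remains open.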